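The compounds below may be only part of what the source reports. "The series", "measured", "known", "first", "only" and "open" are said of these compounds alone.

Within the data shown here, in an ADME assay on a cell-free system (plasma, Homo sapiens) for protein binding, read by LC-MS, using equilibrium dialysis, with a stated time of 4 h (a higher number here means a larger unbound share of the compound, a lower number a smaller unbound share), compound 2 `Cn1ccc(-c2ccc(Cc3cc(C(=O)N[C@@H]4CCCC[C@H]4O)nc4c3ccn4C)cn2)n1` gives 0.12, the higher of the two numbers so far. Compound 1 `Cn1cc(-c2ccc(Cc3cc(C(=O)NC4CCOCC4)nc4c3ccn4C)cn2)cn1` gives 0.04, a gap beyond the usual scatter, but these two compounds differ in more than one place. Compound 3 `Cn1cc(-c2ccc(Cc3cc(C(=O)N[C@@H]4CCCC[C@H]4O)nc4c3ccn4C)cn2)cn1` has the same atoms as compound 2, joined differently: 1-methyl-1H-pyrazol-4-yl in place of 1-methyl-1H-pyrazol-3-yl on an aromatic carbon. Among the measured compounds shown here, no measured pair shows this swap alone. Compound 1 carries the same 1-methyl-1H-pyrazol-4-yl group and gives 0.04, which hints weakly at a lower number, although its other differences leave that gap unassigned. The expected change is small and downward, not beyond the scatter: a 1.3-fold lower number from compound 2 to compound 3 (0.12 log units; within the scatter). For compound 3 the estimated value is 0.09, with an expected range from 0.05 to 0.16.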

Compound 3, unbound fraction: 0.04
Estimate against measurement, compound 3: 2.3-fold (0.35 log units) above; the whole stated range lies above it.
By their numbers in this assay, from the lowest: compounds 1 and 3 (each within the scatter of the next); then compound 2.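

In this assay, 1-methyl-1H-pyrazol-4-yl in place of 1-methyl-1H-pyrazol-3-yl, on an aromatic carbon next to the ring nitrogen, gives a 3.0-fold lower number from compound 2 to compound 3 (0.48 log units; beyond the scatter) even though no atom is gained or lost, so how this ring is joined matters here. With 1-methyl-1H-pyrazol-4-yl held fixed, 2-hydroxycyclohexyl in place of oxan-4-yl on the amide-type nitrogen gives no change at the digits printed from compound 1 to compound 3 (within the scatter), so in this pair that exchange leaves the number unmoved. No measurement at hand explains either step.

As far as these compounds go, whether 1-methyl-1H-pyrazol-3-yl would give the same rise with oxan-4-yl on the amide-type nitrogen remains open. So does what a different group at this aromatic carbon, such as an amine or a carboxylic acid, would do to the unbound fraction.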